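Benzyloxy to diethylamino on the carbonyl carbon

The source may report more compounds than this note shows. Statements on the series, on what has been measured and on what is new or still open speak of the compounds shown alone.

Measured so far:
- compound 1 `COc1ccc(-c2cc3c(OC)cc(OC)cc3n(CC(=O)OCc3ccccc3)c2=O)cc1` gives 10000 nM
- compound 2 `COc1ccc(-c2cc3c(OC)cc(OC)cc3n(CCC(=O)OCc3ccccc3)c2=O)cc1` gives 10000 nM

In a functional assay on T-24 cells (Homo sapiens) for cytotoxicity, read by colorimetric assay and MTT assay (on this read-out lower numbers stand for stronger inhibition and higher numbers for weaker inhibition), compound 2 reads 10000 nM and stands level with compound 1. Compound 3 `CCN(CC)C(=O)CCn1c(=O)c(-c2ccc(OC)cc2)cc2c(OC)cc(OC)cc21` carries diethylamino in place of benzyloxy on a carbonyl carbon. For the measured compounds named here, one measured step bears on this (no change at the digits printed from compound 1 to compound 2 (within the scatter)). Going by the values given here, it alters the chain and keeps the benzyloxy, so no measured step gives a size for the exchange itself. The expectation rests on compound 2 at 10000 nM and on that single flat step. No step beyond the scatter is expected in this assay, and no direction is favoured (no change at the digits printed from compound 2 to compound 3 (within the scatter)). With so little evidence, the range stays wide. Compound 3 is estimated at 10000 nM with an expected range from 4000 nM to 30000 nM for now.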

Compound 3, half-maximal inhibitory concentration: 10000 nM
Compound 3: middle estimate and measured number agree at the digits printed; measured number inside the range.
By their numbers in this assay, from the lowest: compounds 1, 2 and 3 (each within the scatter of the next).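

Diethylamino in place of benzyloxy on a carbonyl carbon now has a size of its own in this assay, with no change at the digits printed from compound 2 to compound 3 (within the scatter), so this position tolerates the loss of the six-membered aromatic ring of carbon only without a step beyond the scatter. The wider exchange of benzyloxycarbonyl for (diethylcarbamoyl)methyl on the saturated chain carbon bound to the aromatic nitrogen reads the same way, with no change at the digits printed from compound 1 to compound 3 (within the scatter). No measurement at hand accounts for this flat reading.

Open, going by these compounds, is whether any group on this carbonyl carbon gives a reading apart from these three compounds, for example a free carboxylic acid or a morpholine amide. Also open, on these data alone, is how a longer chain to the aromatic nitrogen would read in this assay.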